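The source may hold more compounds than are shown below. What is called first, only, known or untested is meant among the compounds shown, and "the series" means these compounds.

Working notes on the series. Compound 1 `Cc1ccc(C(=O)Nc2ncc(Cc3ccc(F)cc3)s2)cc1` has been run in an ADME assay on HepG2 2.2.15 cells (Homo sapiens) for cytotoxicity (on this read-out lower numbers stand for higher toxicity in this test and higher numbers for lower toxicity in this test), and is recorded there as "not toxic" (no number reported), with no number attached. Compound 2 `O=C(Nc1ncc(Cc2ccc(F)cc2)s1)c1ccc(Br)cc1` gives in this assay a reading of > 50000 nM, which is a limit of the test and not a number. The entry for compound 2 is the limit of > 50000 nM in this assay, at which 1 of the 2 values shown sits. Compound 3 `O=C(Nc1ncc(Cc2ccc(F)cc2)s1)c1ccc(Cl)cc1Cl` differs from compound 1 by 2,4-dichlorophenyl in place of 4-methylphenyl on a carbonyl carbon. Within the data shown here, no measured step between any two compounds is available here, so the size of the move from compound 1 to compound 3 in this assay cannot be read from data; with the two known entries both at the benign end, no change beyond the usual scatter is expected in either direction, and a reading that ends at the limit is the likelier outcome. Compound 3 is expected to give about 50000 nM in this assay, estimated between 15000 nM and 100000 nM.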

Compound 3, half-maximal cytotoxic concentration: > 50000 nM
Compound 3: only a limit was reported; the forecaster's own chance of this, stated with the estimate: 70%; the middle value lies on the limit itself.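

Compound 2 and compound 3 both end at a limit of this assay, so no step from compound 2 to compound 3 can be read: the limit of > 50000 nM in this assay, at which 2 of the 3 values shown sit.

The compounds shown leave open whether any other group on the carbonyl carbon would give a numerical reading in this assay.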